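A few compounds are considered here, and "the series" means these few. Any claim that something is new, unique, unknown or untested is made for them only; others in the source may bear on it.

The account begins with compound 1, `Ic1nc2ccccc2o1`. For the measured compounds named here, in a functional assay on NCI-H522 cells (Homo sapiens) for cytotoxicity, with a stated time of 3 days (on this read-out higher numbers stand for weaker inhibition and lower numbers for stronger inhibition), compound 1 gives 11700 nM, the only number reported in this assay among the two compounds measured. The other measured compound is compound 2, `C#Cc1csc(Br)n1`. For compound 2 the result in this assay is a limit of the assay and not a number, > 40000 nM. Compound 1 thus stands as the sole point with a measured value, the remaining result being (the limit of > 40000 nM in this assay, at which 1 of the 2 values shown sits).

The unmeasured compound is compound 3, `C#Cc1nc2ccccc2o1`, which differs from compound 1 by ethynyl in place of iodo on an aromatic carbon. Going by the values given here, no step between two measured compounds is available to guide the size of this change. Among the compounds with values here, compound 2 also carries an ethynyl group, on a different core, and sits at the limit, but no step ties it to compound 1 or to compound 3. Compound 3 is expected to follow a 1.4-fold higher number from compound 1 to compound 3 (0.14 log units; within the scatter), a step that may lean toward weaker inhibition but is not expected to go clearly beyond the scatter. Compound 3 is estimated at 16000 nM, within a range from 5000 nM to 50000 nM.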

Compound 3, half-maximal inhibitory concentration: 1260 nM
The estimate for compound 3 lay 13-fold (1.10 log units) above the measured number, outside the stated range (below it).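

At the aromatic carbon next to the ring nitrogen and next to the ring oxygen, the first step measured in this assay shows that the read-out responds to the group placed there: ethynyl in place of iodo gives a 9.3-fold lower number from compound 1 to compound 3 (0.97 log units; beyond the scatter). This step lies beyond the scatter and runs toward stronger inhibition, so on this core the iodo group of compound 1 is not required for activity, and ethynyl, with its triple bond outside the aromatic rings, is the better of the two groups shown at this carbon. No measured property among the data shown bears on this step, so its cause remains unassigned.

The compounds shown leave open whether the lower number depends on the triple bond itself, or whether an amine, a nitrile or a longer chain such as propynyl at the same carbon would give a number closer to that of compound 3 or to that of compound 1. They also leave open whether ethynyl in place of iodo would give a step of similar size on any other core, as this single step stands on one core only.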